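The compounds below may be only part of what the source reports. "The series", "measured", "known", "first", "only" and "open" are said of these compounds alone.

Measured in an assay on T-REx-293 cells for inhibition of potassium channel subfamily T member 1 (Homo sapiens), read by patch clamp; a lower number here means a stronger inhibitor, a higher number a weaker inhibitor:
compound 1 `Cc1cc(-c2noc([C@H](C)NC(=O)c3cc(C(F)(F)F)nn3C)n2)ncn1` gives 1410 nM
compound 2 `C[C@H](NC(=O)c1cc(C(F)(F)F)nn1C)c1nc(-c2ccnc(C(F)(F)F)c2)no1` gives 40 nM

For the measured compounds named here, compound 2 holds the lower of the two numbers; its only neighbour is compound 1, reached by a 35-fold lower number from compound 1 to compound 2 (1.55 log units; beyond the scatter). Compound 3 `CO[C@H](C)c1cc(-c2noc([C@H](C)NC(=O)c3cc(C(F)(F)F)nn3C)n2)ccn1` differs from compound 2 by 1-methoxyethyl in place of trifluoromethyl on an aromatic carbon. Going by the values given here, the one measured step, a 35-fold lower number from compound 1 to compound 2 (1.55 log units; beyond the scatter), exchanged the whole aromatic ring rather than a single substituent, so it bears only loosely on this change; no measured pair varies a group on the ring of compound 2. A modest loss is expected for compound 3 in this assay, a 3.0-fold higher number from compound 2 to compound 3 (0.48 log units; beyond the scatter), within the width of that single step. Compound 3 is estimated at 120 nM, range 40 nM to 400 nM.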

Compound 3, half-maximal inhibitory concentration: 778 nM
The estimate for compound 3 lay 6.5-fold (0.81 log units) below the measured number; the measured number lies above the stated range.
By their numbers in this assay, from the lowest: compound 2; then compounds 3 and 1 (each within the scatter of the next).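

In this assay, the group next to the ring nitrogen proves decisive, not just the ring: with 1-methoxyethyl in place of trifluoromethyl there is a 19-fold higher number from compound 2 to compound 3 (1.29 log units; beyond the scatter) on the same ring. Against the earlier ring exchange, a 1.8-fold lower number from compound 1 to compound 3 (0.26 log units; within the scatter) leaves the two compounds indistinguishable, so the ring with 1 nitrogen does not alone hold the number of compound 2. Nothing available explains the loss.

Open, going by these compounds, is whether a nitrile, a chlorine or an amine at this place would keep that number. Also open, on these data alone, is how the opposite configuration of the 1-methoxyethyl stereocentre would read.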